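The source may report more compounds than this note shows. Statements on the series, on what has been measured and on what is new or still open speak of the compounds shown alone.

Of the compounds shown here, two that share one core have so far been measured in an assay on isolated protein for binding affinity to adenosine receptor A1 (Bos taurus); on this read-out higher numbers stand for weaker inhibition and lower numbers for stronger inhibition. Compound 1 `COc1ccc(C(=O)Nc2nc(-c3ccccc3)nc3c2nnn3Cc2ccccc2Cl)cc1` gives 20000000 nM in this assay. Compound 2 `Clc1ccccc1Cn1nnc2c(NC3CC3)nc(-c3ccccc3)nc21` gives 11000000 nM in this assay. The two differ in a single place, on a nitrogen attached to the aromatic ring, and the measured step is a 1.8-fold lower number from compound 1 to compound 2 (0.26 log units; within the scatter). Going by the values given here, compound 2 thus stands in a set of only two numbers, and its one neighbour, compound 1, lies within the scatter of it, so the pair cannot be told apart.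

Compound 3 `CC(O)CNc1nc(-c2ccccc2)nc2c1nnn2Cc1ccccc1Cl` has not yet been measured in this assay. It differs from compound 2 at the same nitrogen: 2-hydroxypropyl in place of cyclopropyl on a nitrogen on an aromatic ring. Among the compounds with values here, the only measured step that touches this position is the step from compound 1 to compound 2, which stayed within the scatter even though a large group was swapped for a small one. Nothing measured shows how a 2-hydroxypropyl group behaves here. The step from compound 2 to compound 3 is therefore estimated as no change at the digits printed from compound 2 to compound 3 (within the scatter), meaning no change beyond the scatter. Compound 3 is expected to give about 11000000 nM, with a range from 3000000 nM to 40000000 nM.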

Compound 3, inhibition constant: 32000000 nM
The estimate for compound 3 lay 2.9-fold (0.46 log units) below the measured number; the range from low to high includes it.
By their numbers in this assay, from the lowest: compounds 2, 1 and 3 (each within the scatter of the next, the first and the last beyond it).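

In this assay, going by these compounds alone, the change from cyclopropyl to 2-hydroxypropyl gives a 2.9-fold higher number from compound 2 to compound 3 (0.46 log units; beyond the scatter), a modest move but the first step at this nitrogen to pass beyond the scatter, so the group here can shift the number after all. The shift is small, though: the step to the same 2-hydroxypropyl group from the much larger (4-methoxyphenyl)carbonyl group is a 1.6-fold higher number from compound 1 to compound 3 (0.20 log units; within the scatter), so compound 1 cannot be told apart from either of the others, and only compound 2 and compound 3 separate. This change removes a three-membered carbon ring and adds a hydrogen-bond donor and acceptor in a single move, and nothing available here explains the step or shows which of these differences matters.

A plain propyl group on this nitrogen would pull those differences apart, since it has the open chain without the hydroxyl, and the compounds shown do not reveal whether it would fall with compound 2 or with compound 3. As far as these compounds go, how an amine or a carboxylic acid at the end of a longer chain would behave at this position also remains open.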